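Bicyclic amide heteroaryl versus methoxyphenyl in p300 series

The compounds below may be only part of what the source reports. "The series", "measured", "known", "first", "only" and "open" are said of these compounds alone.

Within the data shown here, compound 3 `COc1ccc(NC(=O)[C@H]2CCCN2C(=O)C2(c3cccc(Cl)c3)CCCC2)cc1` gives 100 nM in an assay on isolated protein for inhibition of histone acetyltransferase p300 (Homo sapiens), with a stated time of 60 min (on this read-out lower numbers stand for stronger inhibition and higher numbers for weaker inhibition), the highest of the three numbers measured so far. Compound 1 `O=C(Nc1ccc2[nH]ccc2n1)[C@H]1CCCN1C(=O)C1(c2cccc(Cl)c2)CCCC1` gives 0.159 nM and compound 2 `O=C(Nc1ccc2[nH]ncc2n1)[C@H]1CCCN1C(=O)C1(c2cccc(Cl)c2)CCCC1` gives 0.159 nM in this assay; the step of no change at the digits printed from compound 1 to compound 2 (within the scatter) shows the two bicyclic groups on the amide nitrogen as equivalent within the scatter. Compound 4 `O=C(Nc1cnc2[nH]ncc2c1)[C@H]1CCCN1C(=O)C1(c2cccc(Cl)c2)CCCC1` carries the change (a group of 9 heavy atoms (6 carbon, 3 nitrogen; one five-membered aromatic ring with 2 hetero atoms, one six-membered aromatic ring with 1 hetero atom) in place of a group of 8 heavy atoms (7 carbon, 1 oxygen; one six-membered aromatic ring of carbon only), on an amide-type nitrogen). Its incoming group matches in counted atoms and rings the group of compound 2, though the attachment differs from that of compound 2. The relevant measured steps run the other way: a 630-fold higher number from compound 1 to compound 3 (2.80 log units; beyond the scatter) and a 630-fold higher number from compound 2 to compound 3 (2.80 log units; beyond the scatter), both large. A bicyclic heteroaryl on the amide nitrogen is therefore expected to bring a large decrease in this assay for compound 4, of size a 100-fold lower number from compound 3 to compound 4 (2.00 log units; beyond the scatter); since the two measured bicyclic groups gave the same number, the new attachment is the main uncertainty. Compound 4 is expected at 1 nM, within 0.15 nM to 10 nM.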

Compound 4, half-maximal inhibitory concentration: 15.9 nM
The estimate for compound 4 lay 16-fold (1.20 log units) below the measured number; the measured number lies above the stated range.
By their numbers in this assay, from the lowest: compounds 1 and 2 (each within the scatter of the next); then compound 4; then compound 3.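

Replacing 4-methoxyphenyl with this bicyclic group on the amide-type nitrogen still improves the number in this assay (a 6.3-fold lower number from compound 3 to compound 4 (0.80 log units; beyond the scatter)), but a bicyclic heteroaryl alone does not restore the level of the earlier pair. The incoming group matches the group of compound 2 in counted atoms and rings, yet changing the attachment gives a large loss (a 100-fold higher number from compound 2 to compound 4 (2.00 log units; beyond the scatter)), and the comparison with the other bicyclic group is of the same size (a 100-fold higher number from compound 1 to compound 4 (2.00 log units; beyond the scatter)), so these counts do not settle the number at this position. No available measurement accounts for this loss.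

On these data alone, whether other attachments of the bicyclic group recover the lost ground remains open. Also open, as far as these compounds go, is how a single pyridine ring or an aminopyridine would compare on the same amide-type nitrogen.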